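From compound 2 to compound 3: a sulfanyl swap

A few compounds are considered here, and "the series" means these few. Any claim that something is new, unique, unknown or untested is made for them only; others in the source may bear on it.

In a functional assay on MGC-803 cells (Homo sapiens) for antiproliferative activity, read by MTT assay, with a stated time of 48 h (a higher number here means a weaker inhibitor, a lower number a stronger inhibitor), compound 1 (`COc1ccc(CN(C(=O)CSc2ccccn2)c2cc(OC)c(OC)c(OC)c2)cc1`) gives 2410 nM and compound 2 (`COc1ccc(CN(C(=O)CCSc2nc3ccccc3o2)c2cc(OC)c(OC)c(OC)c2)cc1`) gives 640 nM, the lower of the two numbers. Compound 3 (`COc1ccc(CN(C(=O)CSc2nnnn2C)c2cc(OC)c(OC)c(OC)c2)cc1`) has not yet been measured. Its difference from compound 2 is (1-methyl-1H-tetrazol-5-yl)sulfanyl in place of ((1,3-benzoxazol-2-yl)sulfanyl)methyl on a saturated chain carbon bound to a carbonyl carbon. Within the data shown here, the one measured step bearing on this is a 3.8-fold lower number from compound 1 to compound 2 (0.58 log units; beyond the scatter), modest but beyond the scatter, and it brought in the group now leaving. Among the measured compounds shown here, no measured compound carries the entering group, so the expectation is loose. The estimated step is a 3.9-fold higher number from compound 2 to compound 3 (0.59 log units; beyond the scatter), of similar size and towards a higher number in this assay. For compound 3 the expected value is 2500 nM, with an estimated range of 800 nM to 7500 nM.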

Compound 3, half-maximal inhibitory concentration: 2490 nM
Estimate against measurement, compound 3: 1.0-fold (0.00 log units) above, within the range that was stated.
By their numbers in this assay, from the lowest: compound 2; then compounds 1 and 3 (each within the scatter of the next).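

In this assay, 2-((1,3-benzoxazol-2-yl)sulfanyl)ethyl giving way to ((1-methyl-1H-tetrazol-5-yl)sulfanyl)methyl brings a 3.9-fold higher number from compound 2 to compound 3 (0.59 log units; beyond the scatter), so a second group on the shorter chain also gives a higher number than the benzoxazole-bearing compound. With the chain held the same, 1-methyl-1H-tetrazol-5-yl in place of pyridin-2-yl on a sulfur brings a 1.0-fold higher number from compound 1 to compound 3 (0.01 log units; within the scatter), so this assay does not tell these two rings apart. Nothing measured here accounts for either step.

Compound 2 differs from compound 1 and from compound 3 in both its ring and its chain, so its lower number cannot be assigned to the benzoxazole or to the ethyl chain alone. On these data alone, how a 1,3-benzothiazol-2-yl group on the sulfur would compare also remains open.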